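A few compounds are considered here, and "the series" means these few. Any claim that something is new, unique, unknown or untested is made for them only; others in the source may bear on it.

In an ADME assay on MT4 cells (Homo sapiens) for cytotoxicity, read by MTT assay, with a stated time of 4 days (a lower number here means that less compound is tolerated, a higher number that more compound is tolerated), compound 2 `Cc1ccccc1-c1cc(C)c(Nc2ccnc(Nc3ccc(C#N)cc3)n2)c(C)c1` gives 3820 nM. For the measured compounds named here, the only other number comes from compound 1 `Cc1cc(-c2cccc(C(F)(F)F)c2)cc(C)c1Nc1ccnc(Nc2ccc(C#N)cc2)n1`, which in this assay gives 4030 nM; the step of a 1.1-fold lower number from compound 1 to compound 2 (0.02 log units; within the scatter) lies within the scatter, so the two compounds cannot be told apart on this read-out. Compound 3 `Cc1cc(-c2c(C)cccc2C)cc(C)c1Nc1ccnc(Nc2ccc(C#N)cc2)n1` differs from compound 2 by methyl in place of hydrogen on an aromatic carbon. Going by the values given here, no measured step exchanges hydrogen for methyl, so the change has no direct precedent here; the one step at hand, a 1.1-fold lower number from compound 1 to compound 2 (0.02 log units; within the scatter), moved the number by less than the scatter even though it swapped a larger group. On that basis no step beyond the scatter is expected in this assay, and the expected step is a 1.0-fold lower number from compound 2 to compound 3 (0.00 log units; within the scatter). Compound 3 is therefore estimated at 3800 nM, within a range from 1900 nM to 7600 nM.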

Compound 3, half-maximal cytotoxic concentration: 2590 nM
Compound 3: the middle estimate sits 1.5-fold (0.17 log units) above what was measured, and the stated range covers the measured number.
By their numbers in this assay, from the lowest: compounds 3, 2 and 1 (each within the scatter of the next).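

In this assay the exchange of hydrogen for methyl at this place, ortho to a large group, now has a direct reading: going from 2-methylphenyl to 2,6-dimethylphenyl gives a 1.5-fold lower number from compound 2 to compound 3 (0.17 log units; within the scatter) and so does not separate the two compounds. The wider exchange of 3-(trifluoromethyl)phenyl for 2,6-dimethylphenyl, with a 1.6-fold lower number from compound 1 to compound 3 (0.19 log units; within the scatter) as its step, does not separate them either, so the three groups seen here cannot be told apart on this read-out. No supporting evidence bears on these results.

As far as these compounds go, all three compounds carry a substituted phenyl group at this place, so it stays open whether an amine or a carboxylic acid on that group would move the number beyond the scatter. From the compounds shown here alone, it also stays open whether a longer chain in place of the added methyl would do so.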